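Removing One Trifluoromethyl From an Inactive Amide

A few compounds are considered here, and "the series" means these few. Any claim that something is new, unique, unknown or untested is made for them only; others in the source may bear on it.

Measured compounds:
compound 1, `O=C(Nc1cc(C(F)(F)F)cc(C(F)(F)F)c1)c1nsnc1O`: > 100000 nM
compound 2, `COc1nsnc1C(=O)Nc1cc(C(F)(F)F)cc(C(F)(F)F)c1`: > 100000 nM
compound 3, `Cn1nc(O)c(C(=O)Nc2cc(C(F)(F)F)cc(C(F)(F)F)c2)n1`: > 100000 nM

The three compounds were tested in an assay on isolated protein for inhibition of mitogen-activated protein kinase kinase kinase 14 (Homo sapiens), read by ADP-Glo, with a stated time of 60 min, in the presence of a further agent that is not named here; a lower number here means a stronger inhibitor, a higher number a weaker inhibitor. In this assay compound 1 reaches no number at all, only a limit. Compound 2 likewise stands at a limit. Compound 3 also stands at a limit. All three therefore sit at the same point, (the limit of > 100000 nM in this assay, at which 3 of the 3 values shown sit), and compound 1 cannot be placed above or below its two companions.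

The measured steps are accordingly unreadable: a step that the two limits leave unreadable from compound 1 to compound 2; a step that the two limits leave unreadable from compound 1 to compound 3; and a step that the two limits leave unreadable from compound 2 to compound 3. All three alter the heterocyclic part of the shared core and leave the aryl ring of compound 1 untouched.

Compound 4, `O=C(Nc1cccc(C(F)(F)F)c1)c1nsnc1O`, changes the other end of the molecule: hydrogen in place of trifluoromethyl on an aromatic carbon. Going by the values given here, no measured step touches this ring, so nothing in the data reads on the size or direction of this change. Since every measured compound sits at the limit of this assay, the step is expected to be a step that the limit leaves unreadable from compound 1 to compound 4, meaning that compound 4 most likely again returns only a limit. Compound 4 is therefore estimated at 150000 nM, with an expected range from 50000 nM to 500000 nM.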

Compound 4, half-maximal inhibitory concentration: > 100000 nM
Compound 4 gave a limit, no number; the forecaster's own chance of this, stated with the estimate: 85%; the middle value lies beyond the limit too.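

In this assay compound 4 gives > 100000 nM, which is a limit and not a number. Compound 1 also stands at a limit, so the step from compound 1 to compound 4 cannot be read: the limit of > 100000 nM in this assay, at which 4 of the 4 values shown sit. The compounds shown leave open the size and direction of this change, and which change to the shared core would give a number in this assay.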